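From thiophen-2-yl to pyridin-3-yl in a cell test

The source may hold more compounds than are shown below. What is called first, only, known or untested is meant among the compounds shown, and "the series" means these compounds.

Compound 1 `Cc1ncc([N+](=O)[O-])n1CCSc1nnc(-c2ccccc2N)o1` measured 4500 nM
Compound 2 `Cc1ncc([N+](=O)[O-])n1CCSc1nnc(-c2cccs2)o1` measured 20500 nM

These numbers come from a functional assay on HepG2 cells (Homo sapiens) for cytotoxicity, read by MTT assay, with a stated time of 48 h (a lower number here means a stronger inhibitor, a higher number a weaker inhibitor), and compound 2 holds the higher of the two values, which makes it the weaker inhibitor of the pair. Compound 3 `Cc1ncc([N+](=O)[O-])n1CCSc1nnc(-c2cccnc2)o1` keeps the shared core and carries pyridin-3-yl in place of thiophen-2-yl on an aromatic carbon and this group has not been tested so far. For the measured compounds named here, only one measured step bears on the change, also a swap of the group on an aromatic carbon: a 4.6-fold higher number from compound 1 to compound 2 (0.66 log units; beyond the scatter) and this modest step lies beyond the scatter. With compound 2 at the top of just two values, a modest step towards a lower number in this assay is expected, though a change within the scatter remains possible. The estimated change is a 1.7-fold lower number from compound 2 to compound 3 (0.23 log units; within the scatter) and it is only an expectation. For compound 3 the expected value is 12000 nM with an estimated range from 4500 nM to 32000 nM as its limits.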

Compound 3, half-maximal inhibitory concentration: 9600 nM
For compound 3 the middle estimate is 1.3-fold (0.10 log units) above the measured one, and the stated range covers the measured number.
By their numbers in this assay, from the lowest: compound 1; then compound 3; then compound 2.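

Replacing thiophen-2-yl with pyridin-3-yl on this aromatic carbon gives a 2.1-fold lower number from compound 2 to compound 3 (0.33 log units; beyond the scatter), so a second swap at this position moves the number beyond the scatter, this time downwards. Replacing 2-aminophenyl with pyridin-3-yl gives a 2.1-fold higher number from compound 1 to compound 3 (0.33 log units; beyond the scatter), which places compound 3 between the other two and turns a single gap into a three-step order, with each group distinct from the others. Nothing measured here explains why the groups fall in this order.

A plain phenyl group would help to show whether the amine of compound 1 goes with its lower number, and pyridin-4-yl would test whether the place of the ring nitrogen matters. On these data alone, how changes elsewhere in the shared core would alter these numbers also remains open.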